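Ethoxycarbonyl to acetyl: the step from compound 1 to compound 4

A few compounds are considered here, and "the series" means these few. Any claim that something is new, unique, unknown or untested is made for them only; others in the source may bear on it.

Compound 1 `C=C(C)[C@@H]1CC=C(Cn2cc(COc3ccc(C4NC(=O)NC(C)=C4C(=O)OCC)cc3)nn2)CC1` is the reference point of this note. In a functional assay on NCI/ADR-RES cells (Homo sapiens) for inhibition, read by sulforhodamine B assay, with a stated time of 48 h (a higher number here means a weaker inhibitor of growth, a lower number a stronger inhibitor of growth), compound 1 gives > 100000 nM, which is a limit of the assay and not a number. Compound 2 `C=C(C)[C@@H]1CC=C(Cn2cc(COc3ccccc3C3NC(=O)NC(C)=C3C(=O)OCC)nn2)CC1` gives > 100000 nM in this assay, also a limit. Compound 3 `C=C(C)[C@@H]1CC=C(Cn2cc(COc3ccc(C4NC(=O)NC(C)=C4C(=O)OCC)cc3OC)nn2)CC1` gives > 100000 nM in this assay, again a limit. The step that the two limits leave unreadable from compound 1 to compound 3 cannot be read due to the limit of > 100000 nM in this assay, at which 3 of the 3 values shown sit. Compound 4 `C=C(C)[C@@H]1CC=C(Cn2cc(COc3ccc(C4NC(=O)NC(C)=C4C(C)=O)cc3)nn2)CC1` differs from compound 1 by methyl in place of ethoxy on a carbonyl carbon, ethoxycarbonyl to acetyl. Among the measured compounds shown here, no measured step bears on this change; every value sits at the limit. Compound 4 is expected to give 150000 nM in this assay, estimated between 50000 nM and 500000 nM. The expected step that the limit leaves unreadable from compound 1 to compound 4 is none beyond the scatter, with a limit again the likely report.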

Compound 4, concentration for total growth inhibition: > 100000 nM
Compound 4 gave a limit, no number (the forecaster's own chance of this, stated with the estimate: 80%); the middle value lies beyond the limit too.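

Compound 4, like compound 1, gives only a limit and not a number, so no step between the two can be read: the limit of > 100000 nM in this assay, at which 4 of the 4 values shown sit.

The compounds shown leave open whether any change to this series gives a readable value.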